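Cytotoxicity notes: from compound 3 toward compound 4

The source may hold more compounds than are shown below. What is called first, only, known or untested is meant among the compounds shown, and "the series" means these compounds.

Measured compounds:
compound 1, `Cn1cnnc1SCC(=O)Nc1ccc(-c2nc(-c3ccccc3)c(-c3ccccc3)n2C)cc1` — 32%
compound 2, `Cc1nnc(SCC(=O)Nc2ccc(-c3nc(-c4ccccc4)c(-c4ccccc4)n3C)cc2)s1` — 34.8%
compound 3, `CN1CCN(CC(=O)Nc2ccc(-c3nc(-c4ccccc4)c(-c4ccccc4)n3C)cc2)CC1` — 18.8%

All three share one core and differ only in the group on the saturated chain carbon bound to the carbonyl carbon. In a functional assay on HT-29 cells (Homo sapiens) for cytotoxicity, read by MTT assay, with a stated time of 24 h, tested at 0.64 ug/mL (on this read-out lower numbers stand for a weaker effect and higher numbers for a stronger effect at the one concentration tested), compound 1 and compound 2 sit within the scatter of each other: a number 2.8 percentage points higher from compound 1 to compound 2 (within the scatter). Compound 3 stands lowest of the three: a number 13.2 percentage points lower from compound 1 to compound 3 (beyond the scatter) and a number 16 percentage points lower from compound 2 to compound 3 (beyond the scatter), both beyond the scatter.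

Compound 4, `CN(C)/C=C/N1CCN(CC(=O)Nc2ccc(-c3nc(-c4ccccc4)c(-c4ccccc4)n3C)cc2)CC1`, keeps the 4-methylpiperazin-1-yl frame of compound 3 and alters it at one point: 2-(dimethylamino)ethenyl in place of methyl on an amine nitrogen in a ring. Within the data shown here, none of the measured steps touches this position; each of them exchanges the whole group on the chain carbon rather than a substituent on the amine nitrogen in a ring, so they give no direct precedent for the size or direction of this step. The closest guide is compound 3 itself at 18.8%. Among the measured compounds shown here, with no measured step bearing on this change, a step of no more than the scatter is expected: a number 2.2 percentage points higher from compound 3 to compound 4 (within the scatter). Compound 4 is estimated at 21%, in a range from 9% to 34%.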

Compound 4, a percentage reported as activity, at one concentration (the size of the read-out at that concentration, not a potency): 3.1%
Beside the measured number, compound 4's estimate is 17.9 percentage points above it; measured number below the stated range.
By their numbers in this assay, from the lowest: compound 4; then compound 3; then compounds 1 and 2 (each within the scatter of the next).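

The substituent on the amine nitrogen in a ring is not a silent position: in this assay, 2-(dimethylamino)ethenyl in place of methyl gives a clear loss (a number 15.7 percentage points lower from compound 3 to compound 4 (beyond the scatter)). This single change lowers the number further than the exchange of the whole group on the chain carbon did, so that the steps from the two sulfur-linked compounds grow (a number 31.7 percentage points lower from compound 2 to compound 4 (beyond the scatter); a number 28.9 percentage points lower from compound 1 to compound 4 (beyond the scatter)) and compound 4 stands lowest of the four. No measurement at hand accounts for the drop.

The compounds shown do not separate the contribution of the double bond from that of the terminal dimethylamino group. A saturated 2-(dimethylamino)ethyl, a plain ethyl or a bare hydrogen on the same nitrogen would bear on this, and the single concentration leaves potency open.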